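An Amino Group Added to Two Related Cores

The source may hold more compounds than are shown below. What is called first, only, known or untested is meant among the compounds shown, and "the series" means these compounds.

Compound 1 has the structure `COc1ccc(-c2cc3[nH]nc(-c4cc(OC)c(OC)c(OC)c4)n3n2)cc1`. In a functional assay on A549 cells (Homo sapiens) for antiproliferative activity, read by MTT assay, with a stated time of 72 h (a lower number here means a stronger inhibitor, a higher number a weaker inhibitor), compound 1 gives 26400 nM. Compound 2, with the structure `COc1ccc(-c2cc3[nH]nc(-c4cc(OC)c(OC)c(OC)c4)n3n2)cc1N`, differs from it by a single change, (amino in place of hydrogen on an aromatic carbon). In this assay compound 2 gives 17400 nM, so the change brought a 1.5-fold lower number from compound 1 to compound 2 (0.18 log units; within the scatter).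

Compound 3, with the structure `COc1ccc(-c2nn3c(-c4ccc(OC)c(OC)c4OC)nnc3s2)cc1`, is built on a different core; the difference between the two cores is not broken down here. In this assay compound 3 gives 2290 nM, which is the lowest of the three numbers, and its steps from both compound 2 and compound 1 lie beyond the scatter.

Compound 4, with the structure `COc1ccc(-c2nn3c(-c4ccc(OC)c(OC)c4OC)nnc3s2)cc1N`, has not yet been measured. It differs from compound 3 by amino in place of hydrogen on an aromatic carbon. The surroundings of the new group are described in the same words for both pairs, so this is the same change that was made from compound 1 to compound 2 on the other core.

For the measured compounds named here, with only one earlier example to rest on, the step from compound 3 to compound 4 is expected to resemble it, because from compound 1 to compound 2 the change gave a 1.5-fold lower number from compound 1 to compound 2 (0.18 log units; within the scatter); the expected step is a 1.4-fold lower number from compound 3 to compound 4 (0.16 log units; within the scatter). For compound 4 in this assay the estimate is 1600 nM, with a likely range from 700 nM to 3600 nM.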

Compound 4, half-maximal inhibitory concentration: 82 nM
Beside the measured number, compound 4's estimate is 20-fold (1.29 log units) above it; the measured number lies below the stated range.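

On the core of compound 3, replacing hydrogen with an amino group, which turns 4-methoxyphenyl into 3-amino-4-methoxyphenyl, gave a 28-fold lower number from compound 3 to compound 4 (1.45 log units; beyond the scatter) in this assay. The size of the step did not carry over from one core to the other, so a step measured on one core was a poor guide to the same change on the other: the same change on two cores in this assay, a 1.5-fold lower number (0.18 log units; within the scatter) from compound 1 to compound 2 and a 28-fold lower number (1.45 log units; beyond the scatter) from compound 3 to compound 4, 18-fold (1.26 log units) apart, beyond the scatter of two such steps What this does not show is which feature of compound 3 makes the amino step so large, since compound 1 and compound 3 differ in more than one place and those differences are not separated here, and two pairs cannot say how the change would behave on a third core.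

The compounds shown leave open whether the amino group itself is needed on the core of compound 3, or whether a hydroxyl group or a methylamino group on the same carbon would give a step of similar size. They also leave open how much the step depends on the neighbouring methoxy group, as every compound here carries one, and an ethoxy group in its place would test this.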